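The compounds below may be only part of what the source reports. "The series", "measured", "known", "first", "only" and "open" are said of these compounds alone.

Measured so far:
compound 1 `Cn1cc(C2CCN=C(N)N2)c2ccccc21` gives 4290 nM
compound 2 `COn1cc(C2CCN=C(N)N2)c2ccccc21` gives "not active" (no number reported)

Among the measured compounds shown here, in a functional assay on HT-29 cells (Homo sapiens) for cytotoxicity, read by sulforhodamine B assay, with a stated time of 72 h (a higher number here means a weaker inhibitor of growth, a lower number a stronger inhibitor of growth), compound 1 gives 4290 nM as the only number, so it cannot yet be ranked against a second number. Compound 2 is recorded as "not active" (no number reported) without a figure. Compound 3 `Cn1cc(C2CCN=C(N)N2)c2ccc(Br)cc21` keeps the core of compound 1 and carries a single change, bromo in place of hydrogen on an aromatic carbon in the structure: bromo in place of hydrogen on an aromatic carbon. For the measured compounds named here, no measured step bears on this change, so the expectation is only a cautious one. A small move toward stronger growth inhibition is expected, with a 1.7-fold lower number from compound 1 to compound 3 (0.23 log units; within the scatter) as the estimated step, and it may not exceed the scatter. In this assay the estimate for compound 3 is 2500 nM with an expected range of 900 nM to 7000 nM on repeat measurement.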

Compound 3, concentration for 50% growth inhibition: 4560 nM
Estimate against measurement, compound 3: 1.8-fold (0.26 log units) below; the range from low to high includes it.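

In this assay, among the compounds shown here, bromo in place of hydrogen on an aromatic carbon gives a 1.1-fold higher number from compound 1 to compound 3 (0.03 log units; within the scatter) and so provides the first readable step. At this carbon of the six-membered aromatic ring, meta to a fused ring and para to a fused ring, the hydrogen can be exchanged for bromo with no step beyond the scatter. No supporting measurement is available to account for this result.

As far as these compounds go, whether an amine, a carboxylic acid or a longer chain at this carbon would leave the number equally unmoved remains open, as does the outcome of bromo on the other aromatic carbons of that ring. Compound 2 carries no number, so any step involving it cannot be read.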